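A chloro substituent added to the phenyl ring of compound 2

The source may report more compounds than this note shows. Statements on the series, on what has been measured and on what is new or still open speak of the compounds shown alone.

Of the compounds shown here, three of one shared core have been measured in a functional assay on A549 cells (Homo sapiens) for cytotoxicity, read by MTT assay, with a stated time of 48 h; a higher number here means a weaker inhibitor, a lower number a stronger inhibitor. Compound 2 `CCOC(=O)c1c(-c2cc3ccccc3oc2=O)nn(-c2ccccc2)c1C(=O)OCC` gives 100000 nM, the highest number of the three. Compound 1 `CCOC(=O)c1c(-c2c(Cl)c3ccccc3oc2=O)nn(-c2ccccc2)c1C(=O)OCC` gives 34000 nM, and compound 3 `COC(=O)c1c(-c2cc3ccccc3oc2=O)nn(-c2ccccc2)c1C(=O)OC` gives 28000 nM; both stand below compound 2 by steps beyond the scatter. Among the measured compounds shown here, the one measured step with a chloro group, a 2.9-fold higher number from compound 1 to compound 2 (0.47 log units; beyond the scatter), shows that removing chloro from the coumarin-bearing part raised the number modestly.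

Compound 4 `CCOC(=O)c1c(-c2cc3ccccc3oc2=O)nn(-c2ccc(Cl)cc2)c1C(=O)OCC` is compound 2 with chloro in place of hydrogen on an aromatic carbon. Here the chloro enters on the phenyl attached to the ring nitrogen, a different place from the chloro of compound 1, so the measured step bears on it only by analogy. A chloro entering might lower the number, as chloro leaving raised it in a 2.9-fold higher number from compound 1 to compound 2 (0.47 log units; beyond the scatter), but the step is expected to stay modest and may fall within the scatter. Compound 4 is expected at 55000 nM, within 20000 nM to 130000 nM, meaning an expected step of a 1.8-fold lower number from compound 2 to compound 4 (0.26 log units; within the scatter).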

Compound 4, half-maximal inhibitory concentration: 35000 nM
For compound 4 the middle estimate is 1.6-fold (0.20 log units) above the measured one; low and high end bracket the measured number.
By their numbers in this assay, from the lowest: compounds 3, 1 and 4 (each within the scatter of the next); then compound 2.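

In this assay, the change from phenyl to 4-chlorophenyl, with the chloro para to a large group, gives a 2.9-fold lower number from compound 2 to compound 4 (0.46 log units; beyond the scatter), so the nitrogen-bound phenyl is a place where the number responds to substitution. The earlier chloro step, a 2.9-fold higher number from compound 1 to compound 2 (0.47 log units; beyond the scatter), came from another part of the molecule, and together the two steps show that chloro at either of these places goes with a lower number than in compound 2, with no listed chloro compound going against this. No measurement shown gives a reason for this step.

The compounds shown leave open whether a methoxy group or an amine on the same phenyl would lower the number as chloro does. They also leave open whether 4-chlorophenyl would have a similar effect on the methyl esters of compound 3.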